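Replacing Fluoro with 2-Cyanophenyl: Expected Tolerance in Lung Cells

The source may hold more compounds than are shown below. What is called first, only, known or untested is meant among the compounds shown, and "the series" means these compounds.

Among the compounds with values here, compound 1 `Cc1c(Cc2ccc(F)cc2)c(=O)oc2cc(OCC(O)CN3CCC(C(N)=O)CC3)ccc12` was tested in an ADME assay on A549 cells (Homo sapiens) for cytotoxicity, read by CellTiter-Glo (a lower number here means that less compound is tolerated, a higher number that more compound is tolerated), where compound 1 gives 89300 nM, the highest of the three numbers known so far. Compound 2 `Cc1c(Cc2cccc(F)c2)c(=O)oc2cc(OCC(O)CN3CCC(C(N)=O)CC3)ccc12` gives 53300 nM, which is a 1.7-fold lower number from compound 1 to compound 2 (0.22 log units; within the scatter). Compound 3 `Cc1c(Cc2cccc3ccccc23)c(=O)oc2cc(OCC(O)CN3CCC(C(N)=O)CC3)ccc12` gives 42400 nM, which is a 2.1-fold lower number from compound 1 to compound 3 (0.32 log units; beyond the scatter). Compound 4 `Cc1c(Cc2ccc(-c3ccccc3C#N)cc2)c(=O)oc2cc(OCC(O)CN3CCC(C(N)=O)CC3)ccc12` is not yet measured; against compound 1 the change is 2-cyanophenyl in place of fluoro on an aromatic carbon. Within the data shown here, only the step to compound 3 enlarges the aromatic part in a comparable way, and it was modest. A similarly modest lowering is therefore expected, a 2.0-fold lower number from compound 1 to compound 4 (0.30 log units; within the scatter). For compound 4 the estimate in this assay is 45000 nM, expected to fall between 20000 nM and 100000 nM.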

Compound 4, half-maximal cytotoxic concentration: 33200 nM
For compound 4 the middle estimate is 1.4-fold (0.13 log units) above the measured one; measured number inside the range.
By their numbers in this assay, from the lowest: compounds 4, 3, 2 and 1 (each within the scatter of the next, the first and the last beyond it).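

Earlier changes only moved the fluoro or exchanged the whole aryl group, whereas compound 4 carries a second ring on the aromatic carbon para to a large group. With 2-cyanophenyl in place of fluoro, this assay shows a 2.7-fold lower number from compound 1 to compound 4 (0.43 log units; beyond the scatter), so even this much larger group of 8 heavy atoms brings only a modest step. No measurement here explains the lowering. The compounds shown do not separate the added ring from its nitrile, which a plain phenyl at this carbon would do. From the compounds shown here alone, how an amine or a carboxylic acid there would behave also stays open.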